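Swapping Bromine for Fluorine on a Triazole Aryl Arm

The source may hold more compounds than are shown below. What is called first, only, known or untested is meant among the compounds shown, and "the series" means these compounds.

Among the compounds with values here, compound 1 `C=C1C(=O)[C@]23C[C@@]1(O)CC[C@H]2c1ccc(OS(=O)(=O)c2ccc(C)cc2)c(C)c1[C@@H]3Cn1cc(-c2ccc(Br)cc2)nn1` gives 1020 nM in a functional assay on HL-60 cells (Homo sapiens) for cytotoxicity, read by MTT assay, with a stated time of 4 days (a lower number here means a stronger inhibitor, a higher number a weaker inhibitor), and is the only numeric value among the three measured structures. Compound 2 `Cc1c(O)ccc2c1[C@H](Cn1cc(-c3ccc(Cl)cc3)nn1)[C@@]13CC(=O)[C@@](C)(CC[C@@H]21)C3` reaches only the limit of > 20000 nM in this assay. Compound 3 `C=C1C[C@]23C[C@@]1(O)CC[C@H]2c1cc(Br)c(O)c(C)c1[C@@H]3Cn1cc(-c2ccc(OC)cc2)nn1` likewise stops at the limit of > 20000 nM in this assay. Two of the three values therefore sit at the limit of > 20000 nM in this assay, at which 2 of the 3 values shown sit. Compound 4 `C=C1C(=O)[C@]23C[C@@]1(O)CC[C@H]2c1ccc(OS(=O)(=O)c2ccc(C)cc2)c(C)c1[C@@H]3Cn1cc(-c2ccc(F)cc2)nn1` differs from compound 1 by fluoro in place of bromo on an aromatic carbon. Within the data shown here, no pair of measured compounds differs in this one place. The step of a 2.0-fold higher number from compound 1 to compound 4 (0.29 log units; within the scatter) in this assay is expected to be modest, probably toward weaker inhibition. Compound 4 is accordingly expected to give 2000 nM, within 700 nM to 6000 nM, in this assay.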

Compound 4, half-maximal inhibitory concentration: 1290 nM
The estimate for compound 4 lay 1.6-fold (0.19 log units) above the measured number; measured number inside the range.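

In this assay, within the data shown here, fluoro in place of bromo gives a 1.3-fold higher number from compound 1 to compound 4 (0.10 log units; within the scatter), the first reading at this aromatic carbon, para to a large group. For this pair, 4-bromophenyl and 4-fluorophenyl cannot be told apart on the triazole arm. Nothing shown here accounts for this step. What the compounds shown leave open is whether an amine or a carboxylic acid on this aromatic carbon would also stay within the scatter of compound 1. On these data alone, it also remains open whether the same swap would read alike without the tosylate of compound 1.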